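Prenylated flavanone series: propoxy in place of 4-fluorophenoxy

This account rests on a few compounds, and the source may have more. Where it says the series, first, only, none or still open, it means among the compounds named here.

Compound 1 `COc1cc2c(cc1CC=C(C)C)C(=O)C[C@@H](c1ccc(Oc3ccc(F)cc3)cc1)O2` is the reference for this step. In a functional assay on A549 cells (Homo sapiens) for inhibition, read by sulforhodamine B assay, with a stated time of 48 h, tested at 50 uM (a lower number here means less inhibition of growth, a higher number more inhibition of growth at the concentration tested), compound 1 gives 27%, the lower of the two numbers recorded so far. The other measured member, compound 2 `COc1cc2c(cc1CC=C(C)C)/C(=N/O)C[C@@H](c1ccc(O)cc1)O2`, differs from compound 1 in more than one place; in this assay compound 2 gives 80%, a gap well beyond the scatter. Since the two compounds differ in several places at once, the gap cannot be attributed to a single change.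

The new member, compound 3 `CCCOc1ccc([C@@H]2CC(=O)c3cc(CC=C(C)C)c(OC)cc3O2)cc1`, carries the change (propyl in place of 4-fluorophenyl on an oxygen on an aromatic ring). Among the compounds with values here, no single-change step is available to set a scale for it. Since nothing in the measured pair isolates this change, a step within the scatter, or a modest one in either direction, is expected, and a step of a number 3 percentage points higher from compound 1 to compound 3 (within the scatter) is taken as the estimate. Compound 3 is therefore expected to give about 30% in this assay, with a range from 10% to 55%.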

Compound 3, percent growth inhibition at one concentration: 43%
For compound 3 the middle estimate is 13 percentage points below the measured one, and the stated range covers the measured number.
By their numbers in this assay, from the lowest: compound 1; then compound 3; then compound 2.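

In this assay, within the data shown here, replacing 4-fluorophenoxy with propoxy gives a number 16 percentage points higher from compound 1 to compound 3 (beyond the scatter), the first reading that isolates a single change. This position therefore responds to what sits on the oxygen, and the aromatic ring of 4-fluorophenyl is not needed to retain growth inhibition at the concentration tested: propyl, with 3 heavy atoms and no ring, stands in its place without a loss. No measurement offered here accounts for this step.

Among these compounds, with only one step at this position, no trend with chain length or ring content can be drawn. Open, on these data alone, is whether a longer chain such as butyl, or a propyl chain ending in an amine or a carboxylic acid, on the same oxygen would move the number further, and in which direction.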